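Swapping the Indole for a Hydroxy-Methoxyphenyl Ring

A few compounds are considered here, and "the series" means these few. Any claim that something is new, unique, unknown or untested is made for them only; others in the source may bear on it.

Compound 2 `CN(C)CCn1cnnc1-c1cc(Oc2ccc(NC(=O)N/N=C/c3c[nH]c4ccccc34)cc2F)ccn1` was tested in a functional assay on NCI-H460 cells (Homo sapiens) for cytotoxicity, read by MTT assay, with a stated time of 72 h (a higher number here means a weaker inhibitor, a lower number a stronger inhibitor), and gives 1630 nM. Among the three measured compounds it holds the second highest number. Its closest neighbour is compound 3 `COc1ccc(/C=N/NC(=O)Nc2ccc(Oc3ccnc(-c4nncn4CCN(C)C)c3)c(F)c2)c(OC)c1OC`, which gives 1790 nM; the step between them is a 1.1-fold higher number from compound 2 to compound 3 (0.04 log units; within the scatter). Far away stands compound 1 `CN(C)CCn1cnnc1-c1cc(Oc2ccc(NC(=O)N/N=C/c3ccc(Cl)cc3Cl)cc2F)ccn1` with 130 nM; from it the steps are a 13-fold higher number from compound 1 to compound 2 (1.10 log units; beyond the scatter) and a 14-fold higher number from compound 1 to compound 3 (1.14 log units; beyond the scatter), both large.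

Compound 4 `COc1ccc(/C=N/NC(=O)Nc2ccc(Oc3ccnc(-c4nncn4CCN(C)C)c3)c(F)c2)cc1O` differs from compound 2 in a single place: 3-hydroxy-4-methoxyphenyl in place of 1H-indol-3-yl on a carbon with a double bond to nitrogen. For the measured compounds named here, no measured step carries exactly this 3-hydroxy-4-methoxyphenyl group, so the expectation rests on analogy. Going by the values given here, the only step that replaces 1H-indol-3-yl by another aromatic group on the carbon with a double bond to nitrogen is a 1.1-fold higher number from compound 2 to compound 3 (0.04 log units; within the scatter), which stayed within the scatter. The entering group, like 2,3,4-trimethoxyphenyl, is a six-membered aromatic ring of carbon only carrying oxygen substituents, and only 2,4-dichlorophenyl in compound 1 gave a markedly lower number. In this assay compound 4 is therefore expected to give 1700 nM, with a likely range from 600 nM to 5000 nM. The expected step of a 1.0-fold higher number from compound 2 to compound 4 (0.02 log units; within the scatter) would stay within the scatter, with no clear direction.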

Compound 4, half-maximal inhibitory concentration: 620 nM
Compound 4: middle estimate off by 2.7-fold (0.44 log units), on the high side; the measured number falls inside the stated range.
By their numbers in this assay, from the lowest: compound 1; then compound 4; then compounds 2 and 3 (each within the scatter of the next).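

In this assay the oxygen-bearing rings on the carbon with a double bond to nitrogen turn out not to be interchangeable: putting 3-hydroxy-4-methoxyphenyl in place of 2,3,4-trimethoxyphenyl gives a 2.9-fold lower number from compound 3 to compound 4 (0.46 log units; beyond the scatter) and shows that the particular oxygen substituents on this ring matter. The same group in place of 1H-indol-3-yl gives a 2.6-fold lower number from compound 2 to compound 4 (0.42 log units; beyond the scatter) even though 2,3,4-trimethoxyphenyl in that same swap stayed within the scatter, so a ring swap at this position can now be seen to shift the number in a case that does not involve chlorine. Compound 4 thus sits in an intermediate place, yet 2,4-dichlorophenyl still holds the lowest number of the four compounds, as a 4.8-fold higher number from compound 1 to compound 4 (0.68 log units; beyond the scatter) makes clear.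

These compounds do not separate the part played by the hydroxy group from that of the methoxy group, and they leave open where a phenyl ring bearing an amine or a carboxylic acid would fall in this series. No measurement is available that explains why these rings differ in this cell assay.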